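The compounds below may be only part of what the source reports. "The series", "measured", "known", "first", "only" and "open" are said of these compounds alone.

Among the compounds with values here, in a functional assay on VCaP cells (Homo sapiens) for antiproliferative activity, read by CCK-8 assay, with a stated time of 6 days (on this read-out higher numbers stand for weaker inhibition and lower numbers for stronger inhibition), compound 2 `CCN(c1ccc(C#N)c(Cl)c1)c1cc(-n2cnc3ccccc32)ccc1C` gives 8560 nM, the only single number among the results reported for this set. Compound 3 `N#Cc1ccc(N2CCCc3c(-c4ccncc4)cccc32)cc1C(F)(F)F` reaches only > 30000 nM, which is a limit of the assay and not a number, as noted in the limit of > 30000 nM in this assay, at which 1 of the 3 values shown sits. For compound 1 `N#Cc1ccc(N2CCc3cc(-c4cccnc4)ccc32)cc1C(F)(F)F` the entry in this assay is "not determined" (no result reported), so no result was reported. Compound 4 `CCN(c1ccc(C#N)c(Cl)c1)c1cc(-n2cccn2)ccc1C` differs from compound 2 in one place: 1H-pyrazol-1-yl in place of 1H-benzimidazol-1-yl on an aromatic carbon. Within the data shown here, no pair of measured compounds isolates such a change, so the size of the step is open. The step is expected to be a 1.3-fold higher number from compound 2 to compound 4 (0.11 log units; within the scatter), close to the scatter, with weaker inhibition somewhat more likely than stronger. Compound 4 is therefore expected to give about 11000 nM in this assay, within a range from 3500 nM to 30000 nM.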

Compound 4, half-maximal inhibitory concentration: 2340 nM
Compound 4: the middle estimate sits 4.7-fold (0.67 log units) above what was measured; the whole stated range lies above it.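

In this assay, 1H-pyrazol-1-yl in place of 1H-benzimidazol-1-yl gives a 3.7-fold lower number from compound 2 to compound 4 (0.56 log units; beyond the scatter) at this place, on an aromatic carbon para to a methyl group. The earlier compounds shown here offered no such pair; this one shows that the six-membered aromatic ring of carbon only in 1H-benzimidazol-1-yl is not needed here for inhibition in this assay. Nothing shown accounts for the size of this step. Going by these compounds, whether an amine, a carboxylic acid or 1H-imidazol-1-yl at this place would keep this gain remains open. A single pair also leaves open whether the same change would act alike on the core of compound 3.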